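A few compounds are considered here, and "the series" means these few. Any claim that something is new, unique, unknown or untested is made for them only; others in the source may bear on it.

Compound 1 `CCn1cc(C(=O)Nc2ccc(C)c([N+](=O)[O-])c2)c(=O)c2cc(F)c(N3CCNC(C)C3)c(F)c21` gives 3900 nM in a functional assay on KB cells (Homo sapiens) for cytotoxicity, read by MTT assay; a higher number here means a weaker inhibitor, a lower number a stronger inhibitor
Compound 2 `CCn1cc(C(=O)Nc2ccc(OC)cc2)c(=O)c2cc(F)c(N3CCNC(C)C3)c(F)c21` gives 2600 nM in this assay

For the measured compounds named here, compound 2 and compound 1 lie within the scatter of each other, so compound 2 stands level with the only other measured compound on these numbers. Compound 3 `CCn1cc(C(=O)Nc2ccc(OC(F)(F)F)cc2)c(=O)c2cc(F)c(N3CCNC(C)C3)c(F)c21` keeps the shared core and differs from compound 2 in one place: trifluoromethyl in place of methyl on an oxygen on an aromatic ring. Going by the values given here, only one measured step bears on this, and it exchanges the group on the same amide-type nitrogen, though it is not the same change. Since a 1.5-fold lower number from compound 1 to compound 2 (0.18 log units; within the scatter) stayed within the scatter, no step beyond the scatter is expected in this assay here. The expected size is a 1.2-fold higher number from compound 2 to compound 3 (0.06 log units; within the scatter) and this estimate stays within the scatter. For compound 3 the estimated value is 3000 nM with an expected range from 1200 nM to 7500 nM in this estimate.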

Compound 3, half-maximal inhibitory concentration: 1400 nM
For compound 3 the middle estimate is 2.1-fold (0.33 log units) above the measured one, within the range that was stated.
By their numbers in this assay, from the lowest: compounds 3, 2 and 1 (each within the scatter of the next, the first and the last beyond it).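

Trifluoromethyl in place of methyl on an oxygen on an aromatic ring gives a 1.9-fold lower number from compound 2 to compound 3 (0.27 log units; within the scatter) in this assay and so, taken alone, does not separate these two compounds. For the compounds shown here, the new compound does, however, yield the only step of the set that passes the scatter: with 4-(trifluoromethoxy)phenyl in place of 4-methyl-3-nitrophenyl on the amide-type nitrogen, the change is a 2.8-fold lower number from compound 1 to compound 3 (0.44 log units; beyond the scatter) and remains modest. Thus the group on this nitrogen has now moved the number measurably, though only across the two most distant members of the series.

Going by these compounds, what a nitrile, a chlorine atom or a dimethylamino group would give in place of the trifluoromethoxy group remains open. Nothing measured alongside these numbers accounts for either step.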